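The compounds below may be only part of what the source reports. "The series", "measured", "known", "first", "only" and "open" are said of these compounds alone.

Measured so far:
- Compound 1 `CCCCOc1ccc(C(=O)/C=C/c2c(/C=C/c3ccc(OC)cc3)cc(OC)cc2OC)cc1`: 12.9 ug/mL
- Compound 2 `CCOc1ccc(C(=O)/C=C/c2c(/C=C/c3ccc(OC)cc3)cc(OC)cc2OC)cc1`: 8 ug/mL

Both values come from a functional assay on HepG2 cells (Homo sapiens) for antiproliferative activity, read by MTT assay, with a stated time of 48 h; on this read-out higher numbers stand for weaker inhibition and lower numbers for stronger inhibition. With only these two numbers, compound 2 at 8 ug/mL cannot be ordered against compound 1 at 12.9 ug/mL, since a 1.6-fold lower number from compound 1 to compound 2 (0.21 log units; within the scatter).

Next in the series is compound 3 `COc1ccc(/C=C/c2cc(OC)cc(OC)c2/C=C/C(=O)c2ccccc2C)cc1`, which carries 2-methylphenyl in place of 4-ethoxyphenyl on a carbonyl carbon. For the measured compounds named here, no measured compound carries 2-methylphenyl, and no measured step replaces the whole group. Going by the values given here, the only step that bears on this change is a 1.6-fold lower number from compound 1 to compound 2 (0.21 log units; within the scatter), which alters just the chain on the group that leaves. Among the compounds with values here, it is therefore a weak guide, showing only that one change at this end of the structure stayed within the scatter. On that limited basis, no shift beyond the scatter is expected in this assay, and no direction can be favoured with confidence. The expected step is a 1.1-fold lower number from compound 2 to compound 3 (0.03 log units; within the scatter). For compound 3 the estimated value is 7.5 ug/mL, with an expected range of 2.5 ug/mL to 20 ug/mL.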

Compound 3, half-maximal inhibitory concentration: 5.3 ug/mL
For compound 3 the middle estimate is 1.4-fold (0.15 log units) above the measured one; the range from low to high includes it.
By their numbers in this assay, from the lowest: compounds 3, 2 and 1 (each within the scatter of the next, the first and the last beyond it).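

In this assay, the first replacement of the whole group on the carbonyl carbon gives a 1.5-fold lower number from compound 2 to compound 3 (0.18 log units; within the scatter), so exchanging 4-ethoxyphenyl (9 heavy atoms, 1 hydrogen-bond acceptor) for 2-methylphenyl (7 heavy atoms, 0 hydrogen-bond acceptors) produces no difference that can be read in this assay. Set against 4-butoxyphenyl, the same 2-methylphenyl group gives a 2.4-fold lower number from compound 1 to compound 3 (0.39 log units; beyond the scatter), the only step in these three compounds beyond the scatter, and a modest one; the oxygen-linked chain on the ring is therefore not required for activity at this level in this assay. Nothing available explains these numbers.

The three compounds do not separate the contribution of the methyl group from that of removing the oxygen-linked chain, and they do not show whether the position of the methyl group on the ring matters. Also open, as far as these compounds go, is how the series would respond at this position to a plain phenyl group, or to a phenyl ring carrying an amine or a carboxylic acid.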